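A few compounds are considered here, and "the series" means these few. Any claim that something is new, unique, unknown or untested is made for them only; others in the source may bear on it.

Compound 2, `CC(C)(C)Cc1csc(N)c1C(=O)c1ccc(Cl)c(Cl)c1`, carries a neopentyl group and an amino group on its five-membered ring and a ketone linking that ring to a dichlorinated benzene ring. In an assay on CHO cells for displacement of a labelled ligand from adenosine receptor A1 (Homo sapiens), read by scintillation counting, tested at 10 uM (a higher number here means more inhibition at the concentration tested (going by the name of the read-out), a lower number less inhibition), compound 2 gives 1%, a value that amounts to essentially no displacement of the labelled ligand. Its nearest relative, compound 1, `CC(C)(C)Cc1csc(N)c1C(=O)c1ccc(Cl)cc1`, lacks one of the two chlorines and gives 1%; the step of no change at the digits printed from compound 1 to compound 2 (within the scatter) shows that the extra chlorine made no difference that rises above the noise of repeated measurement. Compound 3, `CC(C)(C)Cc1c(-c2ccccc2)sc(N)c1C(=O)c1ccc(Cl)c(Cl)c1`, differs from compound 2 in one place: phenyl in place of hydrogen on an aromatic carbon. Going by the values given here, no measured step speaks directly to this change; the only step known, no change at the digits printed from compound 1 to compound 2 (within the scatter), concerns a substituent on the benzene ring, not the five-membered ring, so it gives no guide. With both measured compounds sitting at the bottom of the scale, and no information on how a phenyl at this position behaves, the expectation is that compound 3 stays low, with the step of a number 4 percentage points higher from compound 2 to compound 3 (within the scatter) expected to remain within the scatter. Compound 3 is therefore estimated at 5%, within the range -10% to 30%.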

Compound 3, a percentage reported as inhibition, at one concentration (the size of the read-out at that concentration, not a potency): 1%
Compound 3: middle estimate off by 4 percentage points, on the high side; the measured number falls inside the stated range.
By their numbers in this assay, from the lowest: compounds 1, 2 and 3 (each within the scatter of the next).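

In this assay, going by these compounds alone, placing phenyl on the aromatic carbon next to the ring sulfur gives no change at the digits printed from compound 2 to compound 3 (within the scatter) and so provides the first reading for a group of 6 heavy atoms at this position, which carries hydrogen in both compound 1 and compound 2. Phenyl here brings no displacement of the labelled ligand that can be told from the scatter, and with compound 2 already at the bottom of the scale, this step could only have shown a rise, never a fall, so any harm from phenyl at this position would stay hidden. Nothing measured here offers a reason for this reading.

Still open, from the compounds shown here alone, is whether a different group on this same carbon, such as an amine, a carboxylic acid or a longer carbon chain, would give a reading that rises above the scatter. Also open, going by these compounds, is whether replacing the neopentyl group or the amino group on the shared core, for example with an ethyl group or an amide, would move these compounds off the bottom of the scale.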